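A second chloro on compound 3

The source may hold more compounds than are shown below. What is called first, only, known or untested is meant among the compounds shown, and "the series" means these compounds.

Of the compounds shown here, three sharing one core have been tested in a functional assay on SK-OV-3 cells (Homo sapiens); on this read-out lower numbers stand for stronger inhibition of growth and higher numbers for weaker inhibition of growth. Compound 1 `N#Cc1ccc(/C=C/S(=O)(=O)Cc2ccc(Nc3ncnc4ccccc34)cc2)cc1` gives only a limit, > 100000 nM. Compound 2 `O=S(=O)(/C=C/c1ccc(Cl)c(Cl)c1)Cc1ccc(Nc2ncnc3ccccc23)cc1` reads 22000 nM. Compound 3 `O=S(=O)(/C=C/c1ccc(Cl)cc1)Cc1ccc(Nc2ncnc3ccccc23)cc1` reads 54000 nM, the higher of the two actual numbers, so it has the weaker growth inhibition of that pair.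

The next candidate, compound 4 `O=S(=O)(/C=C/c1ccc(Cl)cc1Cl)Cc1ccc(Nc2ncnc3ccccc23)cc1`, differs from compound 3 by one change: chloro in place of hydrogen on an aromatic carbon. It has chloro in place of hydrogen on an aromatic carbon, ortho to a large group.

Among the compounds with values here, the closest precedent is the loss of a chloro, which gave a 2.5-fold higher number from compound 2 to compound 3 (0.39 log units; beyond the scatter), a modest step beyond the scatter. Compound 2 is a 3,4-dichlorophenyl case, however, while compound 4 is 2,4-dichlorophenyl, so the match is imperfect. Swapping cyano for chloro gave an at least 1.8-fold lower number from compound 1 to compound 3 (0.26 log units; that floor lies within the scatter), a floor within the scatter, and this says little here.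

A modest gain is therefore expected, with the estimated change being a 2.0-fold lower number from compound 3 to compound 4 (0.30 log units; within the scatter). For compound 4 the estimated value is 27000 nM, with an expected range from 11000 nM to 65000 nM.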

Compound 4, concentration for 50% growth inhibition: 2000 nM
Estimate against measurement, compound 4: 14-fold (1.13 log units) above; the whole stated range lies above it.
By their numbers in this assay, from the lowest: compound 4; then compound 2; then compound 3. At a limit, above all of these: compound 1.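

In this assay, within the data shown here, a chloro on the aromatic carbon ortho to a large group proves far more valuable than the earlier compounds hinted, giving a 27-fold lower number from compound 3 to compound 4 (1.43 log units; beyond the scatter) in a single change. The place of the second chloro matters, not only its presence: going from 3,4-dichlorophenyl to 2,4-dichlorophenyl gives an 11-fold lower number from compound 2 to compound 4 (1.04 log units; beyond the scatter) with the count of chloro groups unchanged. Replacing 4-cyanophenyl with 2,4-dichlorophenyl gives an at least 50-fold lower number from compound 1 to compound 4 (1.69 log units; beyond the scatter) as a floor only, and the value of compound 1 is a limit.

From the compounds shown here alone, whether the gain needs both chloro groups stays open, as does whether a 2-chlorophenyl group alone, or a bromo or methoxy group on that same carbon, would do as well. Nothing given here accounts for the size of this gain.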